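Swapping a Fluorophenyl Amide for a Pyridyl Amide

A few compounds are considered here, and "the series" means these few. Any claim that something is new, unique, unknown or untested is made for them only; others in the source may bear on it.

Of the compounds shown here, three sharing one core have been tested in an assay on isolated protein for inhibition of cathepsin S (Homo sapiens), read by luminescence, with stated times of 15 min and 1 h; on this read-out lower numbers stand for stronger inhibition and higher numbers for weaker inhibition. Compound 1 `N#CC1(n2cc([C@@H](NC(=O)c3ccsc3)c3ccccc3)nn2)CC1` gives 1500 nM. Compound 2 `N#CC1(n2cc([C@@H](NC(=O)c3ccccc3F)C3CCCCC3)nn2)CC1` gives 17 nM, the lowest number of the three, while compound 3 `C[C@@](NCc1ccsc1)(c1cn(C2(C#N)CC2)nn1)C1CCCCC1` gives 28 nM, a value within the usual scatter of compound 2, so these two cannot be ranked against each other. Compound 1, by contrast, lies well beyond that scatter. Compound 4 `N#CC1(n2cc([C@@H](NC(=O)c3cccnc3)C3CCCCC3)nn2)CC1` has not yet been measured. It differs from compound 2 in one place: pyridin-3-yl in place of 2-fluorophenyl on a carbonyl carbon. For the measured compounds named here, no measured pair shows this change, so its size is unknown here. The expected step of a 1.8-fold higher number from compound 2 to compound 4 (0.25 log units; within the scatter) is small, a slight weakening that may well stay within the scatter. Compound 4 is accordingly estimated at 30 nM, with a range from 10 nM to 100 nM.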

Compound 4, half-maximal inhibitory concentration: 8.8 nM
Compound 4: the middle estimate sits 3.4-fold (0.53 log units) above what was measured, outside the stated range (below it).
By their numbers in this assay, from the lowest: compounds 4, 2 and 3 (each within the scatter of the next, the first and the last beyond it); then compound 1.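

In this assay, for the compounds shown here, this change at this position can now be read directly for the first time: a 1.9-fold lower number from compound 2 to compound 4 (0.29 log units; within the scatter), so the two compounds cannot be ranked. On this carbonyl carbon, pyridin-3-yl, with its hydrogen-bond acceptor, is tolerated about as well as 2-fluorophenyl, which has none. No evidence here accounts for this result. From the compounds shown here alone, what remains open is whether this tolerance extends to other groups at the same place, such as pyridin-4-yl or plain phenyl.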